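The source may report more compounds than this note shows. Statements on the series, on what has been measured and on what is new or still open speak of the compounds shown alone.

Measured compounds:
compound 1 `CC1=C(C(=O)OC2CCCCC2)C(c2ccco2)NC(=O)N1` gives 1%
compound 2 `CC1=C(C(=O)OCC2CC2)C(c2ccco2)NC(=O)N1` gives 29%
compound 3 `CC1=C(C(=O)OC2CCCCC2)C(c2ccsc2)NC(=O)N1` gives 8%

All three numbers come from an assay on membranes from CHO cells for displacement of a labelled ligand from adenosine receptor A1 (Homo sapiens), read by scintillation counting, with a stated time of 60 min, tested at 1 uM; on this read-out higher numbers stand for more inhibition at the one concentration tested (going by the name of the read-out) and lower numbers for less inhibition. Compound 1 and compound 3 share the cyclohexyl ester and differ in the core by thiophen-3-yl in place of furan-2-yl on a saturated ring carbon; the step of a number 7 percentage points higher from compound 1 to compound 3 (within the scatter) is a small one and says little. For the measured compounds named here, compound 2 carries the core of compound 1 with the change (cyclopropylmethyl in place of cyclohexyl on an oxygen next to a carbonyl group), and this gave a number 28 percentage points higher from compound 1 to compound 2 (beyond the scatter), the one step in the set that stands outside the scatter.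

Compound 4 `CC1=C(C(=O)OCC2CC2)C(c2ccsc2)NC(=O)N1` is not yet measured in this assay. It relates to compound 3 as compound 2 relates to compound 1: the change is cyclopropylmethyl in place of cyclohexyl on an oxygen next to a carbonyl group, and the place where it occurs reads the same in both pairs, so it is the same change, made on the core of compound 3 rather than on the core of compound 1. The change has been seen once among these compounds, between compound 1 and compound 2, and that single precedent is the only guide to its size on the other core.

The step from compound 3 to compound 4 is expected to be a number 24 percentage points higher from compound 3 to compound 4 (beyond the scatter), resting on the earlier step of a number 28 percentage points higher from compound 1 to compound 2 (beyond the scatter). Compound 4 is accordingly expected to give about 32% in this assay. The likely range for compound 4 is estimated to run from 12% to 52%, kept wide since one precedent on a different core is thin support.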

Compound 4, a percentage reported as inhibition, at one concentration (the size of the read-out at that concentration, not a potency): 39%
The estimate for compound 4 lay 7 percentage points below the measured number; measured number inside the range.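

In this assay, cyclopropylmethyl in place of cyclohexyl on an oxygen next to a carbonyl group gives a number 31 percentage points higher from compound 3 to compound 4 (beyond the scatter), which matches its effect on the core of compound 1: the same change on two cores in this assay, a number 28 percentage points higher (beyond the scatter) from compound 1 to compound 2 and a number 31 percentage points higher (beyond the scatter) from compound 3 to compound 4, 3 percentage points apart, within the scatter of two such steps. Thiophen-3-yl in place of furan-2-yl on a saturated ring carbon gives a number 10 percentage points higher from compound 2 to compound 4 (within the scatter), and this change stays within the scatter with either ester group: the same change on two cores in this assay, a number 7 percentage points higher (within the scatter) from compound 1 to compound 3 and a number 10 percentage points higher (within the scatter) from compound 2 to compound 4, 3 percentage points apart, within the scatter of two such steps. Across these four compounds, the ester change therefore carries from one core to the other at much the same size, but this rests on only two cores that differ in a single group, and on inhibition read at one concentration, so it shows neither a change in potency nor that the step would hold on a more distant core.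

Cyclohexyl and cyclopropylmethyl differ in both ring size and the methylene link, so a cyclopropyl ester and a cyclohexylmethyl ester would be needed to tell which of these goes with the step. As far as these compounds go, it also remains open whether the step extends to a longer chain such as n-butyl on the same oxygen, or to an amide or a carboxylic acid in place of the ester.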